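Compound 3 gives up its cyano and fluoro groups

This account rests on a few compounds, and the source may have more. Where it says the series, first, only, none or still open, it means among the compounds named here.

In an in vitro ADME assay on microsomes from liver (Rattus norvegicus) for metabolic stability (a lower number here means slower removal, a higher number faster removal of the compound), compound 1 `CC(C)NC(=O)[C@H]1CC[C@@H](n2/c(=N/C(=O)c3cc(F)cc(Cl)c3)[nH]c3ccc(CN4CCC(C(C)(C)O)CC4)cc32)CC1` gives 43 mL.min-1.g-1, compound 2 `CC(C)NC(=O)[C@H]1CC[C@@H](n2/c(=N/C(=O)c3ccc(F)c(F)c3)[nH]c3ccc(CN4CCC(C(C)(C)O)CC4)cc32)CC1` gives 19 mL.min-1.g-1 and compound 3 `CC(C)NC(=O)[C@H]1CC[C@@H](n2/c(=N/C(=O)c3cc(F)cc(C#N)c3)[nH]c3ccc(CN4CCC(C(C)(C)O)CC4)cc32)CC1` gives 30 mL.min-1.g-1. Compound 3 is not separated from either of the others, since the data show a 1.4-fold lower number from compound 1 to compound 3 (0.16 log units; within the scatter) and a 1.6-fold higher number from compound 2 to compound 3 (0.20 log units; within the scatter). Compound 4 `CC(C)NC(=O)[C@H]1CC[C@@H](n2/c(=N/C(=O)c3ccccc3)[nH]c3ccc(CN4CCC(C(C)(C)O)CC4)cc32)CC1` has phenyl in place of 3-cyano-5-fluorophenyl on a carbonyl carbon. Among the measured compounds shown here, no measured compound carries this unsubstituted phenyl, so the evidence is indirect. For the measured compounds named here, the steps that bear on it are the exchanges of the group on the same carbonyl carbon. The largest is a 2.3-fold lower number from compound 1 to compound 2 (0.35 log units; beyond the scatter), which is modest, and the other two stay within the scatter. Changes at this place have therefore moved this assay only slightly, and no clear direction can be drawn for the loss of both groups. The expected step is a 1.2-fold lower number from compound 3 to compound 4 (0.08 log units; within the scatter), and no change beyond the scatter is expected. The estimate for compound 4 is 25 mL.min-1.g-1, with an expected range from 12 mL.min-1.g-1 to 55 mL.min-1.g-1.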

Compound 4, intrinsic clearance in microsomes: 21 mL.min-1.g-1
Compound 4: middle estimate off by 1.2-fold (0.08 log units), on the high side; low and high end bracket the measured number.
By their numbers in this assay, from the lowest: compounds 2, 4, 3 and 1 (each within the scatter of the next, the first and the last beyond it).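

Compound 4 shows that at this place, on a carbonyl carbon, a phenyl with no substituents at all still falls in with two of the substituted compounds in this assay: the data give a 1.4-fold lower number from compound 3 to compound 4 (0.15 log units; within the scatter) and a 1.1-fold higher number from compound 2 to compound 4 (0.04 log units; within the scatter), so losing the cyano and fluoro groups of the 3-cyano-5-fluorophenyl, or both fluoro groups of the 3,4-difluorophenyl, brings no separated change. Only the exchange of 3-chloro-5-fluorophenyl stands apart, with a 2.0-fold lower number from compound 1 to compound 4 (0.31 log units; beyond the scatter), and compound 1 is now separated from both compound 2 and compound 4, while compound 3 remains unseparated from all three. Nothing in the data offered here accounts for this.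

Chloro appears only in compound 1, so whether that group alone sets compound 1 apart stays open. Also open, on these data alone, is how this assay responds if the phenyl carries a carboxylic acid or a dimethylamino group, or gives way to cyclohexyl.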